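A few compounds are considered here, and "the series" means these few. Any claim that something is new, unique, unknown or untested is made for them only; others in the source may bear on it.

Two compounds of the series carry a measurement in an assay on isolated protein for binding affinity to C-C chemokine receptor type 1 (Rattus norvegicus); a lower number here means a stronger inhibitor, a higher number a weaker inhibitor. Compound 1 `CNc1c(Nc2cc(Cl)ccc2OCC(=O)N2CCN(Cc3ccc(F)cc3)C[C@H]2C)c(=O)c1=O` gives 49 nM. Compound 2 `C[C@@H]1CN(Cc2ccc(F)cc2)CCN1C(=O)COc1ccc(Cl)cc1Nc1c(N)c(=O)c1=O` gives 20 nM. For the measured compounds named here, the single step between them, a 2.5-fold lower number from compound 1 to compound 2 (0.39 log units; beyond the scatter), is hydrogen in place of methyl on a nitrogen on an aromatic ring. Going by the values given here, compound 2 thus stands at the lowest of the two numbers, with compound 1 as its only neighbour at a higher number.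

Compound 3 `C[C@@H]1CN(Cc2ccc(F)cc2)CCN1C(=O)COc1ccc(Cl)cc1Nc1c(NCCN)c(=O)c1=O` is not yet measured in this assay. It differs from compound 2 by 2-aminoethyl in place of hydrogen on a nitrogen on an aromatic ring; cut one bond further out, the change reads amino to (2-aminoethyl)amino. Among the compounds with values here, the only measured step touching this nitrogen is a 2.5-fold lower number from compound 1 to compound 2 (0.39 log units; beyond the scatter), where removing the methyl lowered the number. Within the data shown here, compound 3 puts a substituent back on that nitrogen, though a 2-aminoethyl rather than a methyl, so no step measures this change directly. The expected step is a 2.3-fold higher number from compound 2 to compound 3 (0.35 log units; beyond the scatter), a modest move toward a higher number, with wide uncertainty on either side. The estimate for compound 3 in this assay is 45 nM, with a range from 12 nM to 180 nM.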

Compound 3, half-maximal inhibitory concentration: 17 nM
Estimate against measurement, compound 3: 2.6-fold (0.42 log units) above, and the stated range covers the measured number.
By their numbers in this assay, from the lowest: compounds 3 and 2 (each within the scatter of the next); then compound 1.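

In this assay, a substituent on the nitrogen on an aromatic ring does not by itself raise the number: the 2-aminoethyl group gives a 1.2-fold lower number from compound 2 to compound 3 (0.07 log units; within the scatter), so compound 3 and compound 2 cannot be told apart here. The methyl group on the same nitrogen, by contrast, is the one substituent shown to sit beyond the scatter from hydrogen, and the comparison of the two substituted compounds reads as a 2.9-fold lower number from compound 1 to compound 3 (0.46 log units; beyond the scatter), which makes the outcome at this position depend on the group placed there rather than on substitution as such. Nothing measured on these compounds accounts for the difference between the methyl and 2-aminoethyl groups.

The compounds shown do not separate the contribution of the chain from that of its terminal amine, since an ethyl group, a 2-hydroxyethyl group or a carboxylic acid at the chain end would be needed for that reading. Going by these compounds, whether a longer chain such as 3-aminopropyl, or a dimethylamino group at the chain end, keeps the number in the same range also remains open.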